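The source may hold more compounds than are shown below. What is called first, only, known or untested is meant among the compounds shown, and "the series" means these compounds.

Of the compounds shown here, two have been tested. Compound 1 `CC(C)(C)Cc1c(-c2ccc(F)cc2F)sc(N)c1C(=O)c1ccc(Cl)cc1` in an assay on CHO cells for displacement of a labelled ligand from adenosine receptor A1 (Homo sapiens), read by scintillation counting, tested at 10 uM (a lower number here means less inhibition, a higher number more inhibition at the concentration tested (going by the name of the read-out)), gives 1%, and compound 2 `COc1ccc(-c2sc(N)c(C(=O)c3ccc(Cl)cc3)c2CC(C)(C)C)cc1` in this assay gives 1%. The step of no change at the digits printed from compound 1 to compound 2 (within the scatter) shows that swapping the aryl group on the shared core made no detectable difference, so compound 2 stands level with compound 1, both at the bottom of the scale.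

Compound 3 `CC(C)(C)Cc1c(-c2cn[nH]c2)sc(N)c1C(=O)c1ccc(Cl)cc1` is the next member. It differs from compound 2 as follows: 1H-pyrazol-4-yl in place of 4-methoxyphenyl on an aromatic carbon. The newcomer is a small ring with a hydrogen-bond donor, set on an aromatic carbon of the five-membered ring next to the ring sulfur and next to the ring atom that bears the neopentyl group.

Within the data shown here, only one measured step bears on this change, the swap from compound 1 to compound 2, and it produced no change beyond the scatter. With two aryl groups giving the same low result, the expectation for a third group on the same carbon is again a small step, a number 2 percentage points higher from compound 2 to compound 3 (within the scatter), with no direction preferred. For compound 3 the estimated value is 3%, expected to lie between -8% and 18%.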

Compound 3, a percentage reported as inhibition, at one concentration (the size of the read-out at that concentration, not a potency): 1%
For compound 3 the middle estimate is 2 percentage points above the measured one; low and high end bracket the measured number.
By their numbers in this assay, from the lowest: compounds 1, 2 and 3 (each within the scatter of the next).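

In this assay the pyrazole gives no change at the digits printed from compound 2 to compound 3 (within the scatter), and the same holds for no change at the digits printed from compound 1 to compound 3 (within the scatter). Until now this aromatic carbon had carried only six-membered rings of carbon, so the result extends the flat picture to a five-membered aromatic ring with two nitrogens and a hydrogen-bond donor, which shows that even this different ring does not separate itself from the two aryl groups in this read-out. All three compounds sit at the low end of the scale, where a group's influence may not be visible at all, and no evidence is available to explain why the numbers match.

Still open, as far as these compounds go, is whether a basic amine such as a piperazine, a carboxylic acid or a longer alkyl chain on this same carbon would give a number that stands clear of the scatter. Also open, from the compounds shown here alone, is whether replacing the neopentyl group, the amino group or the (4-chlorophenyl)carbonyl group would raise the inhibition, and whether this aromatic carbon would then matter.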